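One Methyl Fewer on an Amide-Type Nitrogen

The source may report more compounds than this note shows. Statements on the series, on what has been measured and on what is new or still open speak of the compounds shown alone.

Compound 1 `CC(NC(=O)NS(=O)(=O)c1ccccc1)c1cc(Br)ccc1OCc1ccccc1` gives 130000 nM
Compound 2 `Cc1ccc(S(=O)(=O)NC(=O)NC(C)c2cc(C)ccc2OCc2ccccc2)cc1` gives 91900 nM
Compound 3 `Cc1ccc(OCc2ccccc2)c(C(C)NC(=O)N(C)S(=O)(=O)c2ccccc2)c1` gives 68200 nM

All three values come from a functional assay on thoracic aorta (Rattus norvegicus, strain Wistar), with a stated time of 15 min (on this read-out lower numbers stand for an effect already at smaller amounts and higher numbers for an effect only at larger amounts of compound), and lie within the usual scatter of one another. Compound 3 at 68200 nM therefore cannot be separated from compound 1 or compound 2. Compound 4 `Cc1ccc(OCc2ccccc2)c(C(C)NC(=O)NS(=O)(=O)c2ccccc2)c1` remains unmeasured. It differs from compound 3 by hydrogen in place of methyl on an amide-type nitrogen and so has hydrogen in place of methyl on an amide-type nitrogen. Going by the values given here, no measured pair isolates this change. Compound 1 and compound 2 also carry that hydrogen, yet compound 2 at 91900 nM stays within the scatter of compound 3. The step of a 1.3-fold higher number from compound 3 to compound 4 (0.12 log units; within the scatter) is therefore expected to remain within the scatter. Compound 4 is estimated at 90000 nM in this assay with an expected range of 40000 nM to 200000 nM overall.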

Compound 4, half-maximal effective concentration: > 200000 nM
Compound 4 gave a limit, no number; the forecaster's own chance of this, stated with the estimate: 10%; middle value at least 2.2-fold (0.34 log units) away from the limit.
By their numbers in this assay, from the lowest: compounds 3, 2 and 1 (each within the scatter of the next). At a limit, above all of these: compound 4.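

Compound 4 stands at a limit in this assay, not at a number: the limit of > 200000 nM in this assay, at which 1 of the 4 values shown sits. Hydrogen in place of methyl on an amide-type nitrogen whose other neighbours are the carbonyl carbon and the sulfonyl sulfur gives an at least 2.9-fold higher number from compound 3 to compound 4 (0.46 log units; beyond the scatter). Hydrogen in place of methyl on an aromatic carbon gives an at least 2.1-fold higher number from compound 2 to compound 4 (0.33 log units; beyond the scatter), whereas methyl in place of bromo on an aromatic carbon gives an at least 1.5-fold higher number from compound 1 to compound 4 (0.18 log units; that floor lies within the scatter).

On these data alone, how far compound 4 actually lies beyond its limit remains open. So does whether ethyl or acetyl on that nitrogen would behave like methyl.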